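The source may hold more compounds than are shown below. What is called first, only, known or untested is meant among the compounds shown, and "the series" means these compounds.

Working notes on the series: in an ADME assay on cells (Hepatocyte, Rattus norvegicus, strain Wistar) for pharmacokinetics, read by LC-MS, with a stated time of 90 min, tested at 1 uM (on this read-out lower numbers stand for slow clearance and higher numbers for fast clearance), compound 1 `COc1cc(C(=O)N2CC(C)OCC2CO)cc2nc(N[C@H](C)c3cccc(Cl)c3)oc12` gives 15.5 mL/min/kg, the lower of the two numbers so far, and compound 2 `COc1cc(C(=O)N2C[C@@H](C)OC[C@H]2CCO)cc2nc(N[C@H](C)c3cccc(Cl)c3)oc12` gives 38.3 mL/min/kg. Compound 3 `COc1cc(C(=O)N2CC(C)OCC2C2CC(O)C2)cc2nc(N[C@H](C)c3cccc(Cl)c3)oc12` is still unmeasured, and its change from compound 1 is 3-hydroxycyclobutyl in place of hydroxymethyl on a saturated ring carbon. For the measured compounds named here, only one measured step replaces the same hydroxymethyl, with 2-hydroxyethyl, and it is modest: a 2.5-fold higher number from compound 1 to compound 2 (0.39 log units; beyond the scatter). On that single step, a rise of similar size is expected in this assay, with wide uncertainty. The expected step is a 1.9-fold higher number from compound 1 to compound 3 (0.29 log units; within the scatter). For compound 3 the estimate is 30 mL/min/kg, with an expected range of 14 mL/min/kg to 60 mL/min/kg.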

Compound 3, clearance: 56.7 mL/min/kg
Compound 3: the middle estimate sits 1.9-fold (0.28 log units) below what was measured, within the range that was stated.
By their numbers in this assay, from the lowest: compound 1; then compounds 2 and 3 (each within the scatter of the next).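

In this assay a second replacement of hydroxymethyl on this saturated ring carbon also raises the number, with 3-hydroxycyclobutyl giving a 3.7-fold higher number from compound 1 to compound 3 (0.56 log units; beyond the scatter). The step of a 2.5-fold higher number from compound 1 to compound 2 (0.39 log units; beyond the scatter) therefore no longer stands alone, and hydroxymethyl carries the lowest number of the three groups shown, with both steps beyond the scatter. Nothing available accounts for these rises.

Still open, from the compounds shown here alone, is whether any replacement at this position keeps the number near that of compound 1. An aminomethyl or a plain methyl group, neither carrying the hydroxyl, would test this.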